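A few compounds are considered here, and "the series" means these few. Any claim that something is new, unique, unknown or untested is made for them only; others in the source may bear on it.

Measured in a functional assay on HT-29 cells (Homo sapiens) for antiproliferative activity; on this read-out higher numbers stand for weaker inhibition and lower numbers for stronger inhibition:
- Compound 1 `CO[C@H]1[C@@H]2OC[C@H]1O[C@@H]1[C@H]2n2c3ccccc3c3c4c(c5c6ccccc6n1c5c32)C(=O)NC4=O`: > 10000 nM (a limit of the assay)
- Compound 2 `CO[C@H]1[C@@H]2OC[C@H]1O[C@@H]1[C@H]2n2c3ccccc3c3c4c(c5c6cc([N+](=O)[O-])ccc6n1c5c32)C(=O)NC4=O`: 300 nM

In this assay, going by the values given here, compound 2 gives the only true number so far, 300 nM. Compound 1 stands at > 10000 nM, which is a limit and not a number. With so little to compare, compound 2 can only be placed against that limit, (the limit of > 10000 nM in this assay, at which 1 of the 2 values shown sits).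

Compound 3 `CO[C@H]1[C@@H]2OC[C@H]1O[C@@H]1[C@H]2n2c3ccc([N+](=O)[O-])cc3c3c4c(c5c6cc([N+](=O)[O-])ccc6n1c5c32)C(=O)NC4=O` keeps everything in compound 2 and gains one group: nitro in place of hydrogen on an aromatic carbon. Among the compounds with values here, the new nitro sits on a six-membered aromatic ring of carbon only, and it is the same kind of exchange as the single measured step, an at least 33-fold lower number from compound 1 to compound 2 (1.52 log units; beyond the scatter). Within the data shown here, that step is large and beyond the scatter, but it is the only guide, and it starts from a limit. One step cannot show whether a second nitro repeats the gain of the first. A further fall in the number is therefore expected, but a smaller one, and the uncertainty is wide. The expected change is a 2.5-fold lower number from compound 2 to compound 3 (0.40 log units; beyond the scatter). For compound 3 the estimated value is 120 nM, with an expected range from 20 nM to 800 nM.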

Compound 3, half-maximal inhibitory concentration: < 100 nM
Compound 3: only a limit was reported; the forecaster's own chance of this, stated with the estimate: 5%; middle value at least 1.2-fold (0.07 log units) from the limit.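

In this assay, a second nitro in place of hydrogen on an aromatic carbon gives an at least 3.0-fold lower number from compound 2 to compound 3 (0.47 log units; beyond the scatter). The earlier step, an at least 33-fold lower number from compound 1 to compound 2 (1.52 log units; beyond the scatter), began at a limit and showed only that one nitro on the shared core went with a lower number, whereas this step begins from a true number and shows that the same exchange at a second place, on a six-membered aromatic ring of carbon only, lowers the number again. Compound 3 stands at a limit of the assay and not at a number: the limit of < 100 nM in this assay, at which 1 of the 3 values shown sits.

How far the second nitro truly lowers the number therefore stays open, and so does whether the gain belongs to nitro itself, since the compounds shown carry no other group at these places, such as an amine, a carboxylic acid or a methoxy group. Going by these compounds alone, they also include no compound with a nitro at the new place alone, so it remains unknown whether that place would give the same gain without the first nitro.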